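Working notes on the chain terminus of compound 3

The source may report more compounds than this note shows. Statements on the series, on what has been measured and on what is new or still open speak of the compounds shown alone.

compound 1 `C/N=C(/NC#N)NCCCCCn1nc(-c2ccccc2)ccc1=O` — 100 mg/kg
compound 2 `CCC/N=C(/NC#N)NCCCCn1nc(-c2ccccc2)ccc1=O` — > 100 mg/kg

In a functional assay on the whole organism (stomach) with Rattus norvegicus as the target (on this read-out higher numbers stand for an effect only at larger amounts of compound and lower numbers for an effect already at smaller amounts), compound 1 gives 100 mg/kg. For compound 2 this assay gives only > 100 mg/kg, a limit of the assay and not a number. Compound 2 thus stands at the limit of > 100 mg/kg in this assay, at which 1 of the 2 values shown sits.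

Compound 3 `CC/N=C(\S)NCCCCn1nc(-c2ccccc2)ccc1=O` differs from compound 2 by a group of 5 heavy atoms (3 carbon, 1 nitrogen, 1 sulfur; no ring) in place of a group of 8 heavy atoms (5 carbon, 3 nitrogen; no ring), on an amine nitrogen. Within the data shown here, no measured pair covers a change of this kind, and with compound 2 known only as a limit no direction beyond the scatter can be argued. The estimate for compound 3 in this assay is 100 mg/kg, with a range from 30 mg/kg to 300 mg/kg. The expected step of a number no higher from compound 2 to compound 3 (the limit leaves the size open) is not taken to exceed the scatter.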

Compound 3, dose for half-maximal effect: 37.2 mg/kg
The estimate for compound 3 lay 2.7-fold (0.43 log units) above the measured number; the range from low to high includes it.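

Among these compounds, with the group of 5 heavy atoms (3 carbon, 1 nitrogen, 1 sulfur) on the amine nitrogen, this assay now shows an at least 2.6-fold lower number from compound 2 to compound 3 (0.42 log units; beyond the scatter) and thus a first step beyond the scatter at this position. Going by these compounds, for compound 2 the value > 100 mg/kg is a limit of the assay and not a number, so the true size of that step stays unknown. Measured against a number, the wider change on the saturated chain carbon gives a 2.7-fold lower number from compound 1 to compound 3 (0.43 log units; beyond the scatter) as its step.

On these data alone, whether the sulfur or the loss of the nitrile carries the step stays open. So does the effect of an oxygen in place of the sulfur or of a longer chain on the terminal nitrogen.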